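This account rests on a few compounds, and the source may have more. Where it says the series, first, only, none or still open, it means among the compounds named here.

Measured compounds in the series:

Compound 1: `COc1ccc(/C(C)=C(/C)C(=O)NC2CC2)cc1`, 300 mg/kg
Compound 2: `C/C(C(=O)NC1CC1)=C(\C)c1ccc(C)cc1`, 280 mg/kg

Both numbers come from a toxicity assay on the whole organism (strain Icem-CET (SPF Caw)) for cytotoxicity, with Mus musculus as the target; on this read-out higher numbers stand for an effect only at larger amounts of compound and lower numbers for an effect already at smaller amounts. Compound 1 and compound 2 share the same amide core and differ only at the aromatic substituent; the step of a 1.1-fold lower number from compound 1 to compound 2 (0.03 log units; within the scatter) leaves the two within the scatter of each other, so neither is separated from the other on this read-out. Compound 2 therefore stands beside compound 1 with no distinction that the data can support.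

Compound 3 is `C=CCNC(=O)/C(C)=C(/C)c1ccc(C)cc1`. The change from compound 2 to compound 3 is allyl in place of cyclopropyl on an amide-type nitrogen. Among the measured compounds shown here, the single measured step, a 1.1-fold lower number from compound 1 to compound 2 (0.03 log units; within the scatter), concerns the aromatic substituent and not the amide nitrogen, so no measured step bears directly on this change. For the measured compounds named here, there is nothing to suggest a shift at the amide nitrogen, and the one step that is known was within the scatter. The expectation for compound 3 is accordingly no step beyond the scatter, no change at the digits printed from compound 2 to compound 3 (within the scatter), with the range widened for lack of a direct precedent. The estimated value for compound 3 in this assay is 280 mg/kg, within 140 mg/kg to 560 mg/kg.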

Compound 3, dose for half-maximal effect: 280 mg/kg
Compound 3: the middle estimate sits on the measured number at the digits printed; the measured number falls inside the stated range.
By their numbers in this assay, from the lowest: compounds 2, 3 and 1 (each within the scatter of the next).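

In this assay, among the compounds shown here, the exchange of cyclopropyl for allyl on the amide-type nitrogen gives no change at the digits printed from compound 2 to compound 3 (within the scatter) and provides the first measured step at this position, since the earlier step concerned only the aromatic substituent. The two groups each hold 3 heavy atoms, yet one carries a three-membered non-aromatic ring and the other has no ring and 1 double bond outside aromatic rings, and this difference leaves the compounds unseparated on this read-out, at least with methyl on the aromatic carbon. No supporting measurement is available to explain why the two compounds read alike.

Going by these compounds, whether a more distant departure on the amide-type nitrogen, such as a longer chain like butyl, a chain ending in a carboxylic acid or one ending in an amine, would give a step beyond the scatter remains open. Also open, on these data alone, is whether allyl on this nitrogen reads the same when methoxy takes the place of methyl on the aromatic carbon, since the two changes are seen here only one at a time.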